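Swapping the oxime for a dimethylhydrazone on a tricyclic core

The source may hold more compounds than are shown below. What is called first, only, known or untested is meant among the compounds shown, and "the series" means these compounds.

Three compounds share one core and differ in the side chain attached to it. Compound 1 `N/C(S)=N/N=C/c1c(Cl)n(C2O[C@H](CO)[C@@H](O)[C@H]2O)c2cc(Cl)c(Cl)cc12` carries a thiosemicarbazone, compound 2 `NC(=O)c1c(Cl)n(C2O[C@H](CO)[C@@H](O)[C@H]2O)c2cc(Cl)c(Cl)cc12` a primary amide, and compound 3 `OC[C@H]1OC(n2c(Cl)c(/C=N/O)c3cc(Cl)c(Cl)cc32)[C@H](O)[C@@H]1O` an oxime. In a functional assay on KB cells (Homo sapiens) for cytotoxicity, read by spectrophotometry and crystal violet staining (on this read-out higher numbers stand for weaker inhibition and lower numbers for stronger inhibition), compound 1 gives 65000 nM, compound 2 gives 45000 nM, and compound 3 gives 25000 nM. Compound 3 therefore has the lowest number of the three: the step of a 2.6-fold lower number from compound 1 to compound 3 (0.41 log units; beyond the scatter) lies beyond the scatter, whereas the step of a 1.8-fold lower number from compound 2 to compound 3 (0.26 log units; within the scatter) does not, and neither does a 1.4-fold lower number from compound 1 to compound 2 (0.16 log units; within the scatter).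

Compound 4 `CN(C)/N=C/c1c(Cl)n(C2O[C@H](CO)[C@@H](O)[C@H]2O)c2cc(Cl)c(Cl)cc12` keeps the whole of compound 3 except for one change: dimethylamino in place of hydroxy on a double-bonded nitrogen. Among the measured compounds shown here, the only measured step at that same double-bonded nitrogen is a 2.6-fold lower number from compound 1 to compound 3 (0.41 log units; beyond the scatter), which replaced a larger thiosemicarbazone with the small hydroxy and moved the number modestly downward. The dimethylamino of compound 4 sits between those two in size, so a modest rise in the number, or no step beyond the scatter, is the reasonable expectation in this assay. For compound 4 the expected step is a 1.4-fold higher number from compound 3 to compound 4 (0.15 log units; within the scatter). The estimate for compound 4 is thus 35000 nM, with a likely range from 15000 nM to 90000 nM.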

Compound 4, half-maximal inhibitory concentration: 70000 nM
Compound 4: the middle estimate sits 2.0-fold (0.30 log units) below what was measured; measured number inside the range.
By their numbers in this assay, from the lowest: compounds 3, 2, 1 and 4 (each within the scatter of the next, the first and the last beyond it).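

In this assay, among the compounds shown here, dimethylamino in place of hydroxy on a double-bonded nitrogen gives a step beyond the scatter (a 2.8-fold higher number from compound 3 to compound 4 (0.45 log units; beyond the scatter)), so this nitrogen does not accept every small group equally: the one swap that changes only this group undoes the advantage of the oxime. Compound 4 cannot be told apart from the thiosemicarbazone (a 1.1-fold higher number from compound 1 to compound 4 (0.03 log units; within the scatter)) or from the primary amide (a 1.6-fold higher number from compound 2 to compound 4 (0.19 log units; within the scatter)), so among the groups shown on this nitrogen, only hydroxy stands apart, and even then only from dimethylamino and the thiosemicarbazone, while the number does not simply follow group size, since dimethylamino, with fewer heavy atoms than the group it is compared with in compound 1, sits level with it. Nothing measured here accounts for the rise.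

The step from compound 3 to compound 4 changes the heavy-atom count and removes a hydrogen-bond donor at once, which leaves open which of the two goes with the lower number. A methoxy or a plain amino on the same nitrogen would separate those two changes.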